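Swapping a Pyrrole for a Thiophene

The source may report more compounds than this note shows. Statements on the series, on what has been measured and on what is new or still open speak of the compounds shown alone.

Compound 1 `COc1ccc(-c2c[nH]cc2C(c2ccc(Cl)cc2Cl)n2ccnc2)cc1`: 14800 nM
Compound 2 `Clc1ccc(C(c2c[nH]cc2-c2ccc(Cl)cc2-n2cccc2)n2ccnc2)c(Cl)c1`: 7670 nM

In an ADME assay on L6 cells (Rattus norvegicus) for cytotoxicity, read by fluorescence and resazurin assay, with a stated time of 72 h (a lower number here means that less compound is tolerated, a higher number that more compound is tolerated), compound 2 gives 7670 nM, which lies within the usual scatter of compound 1, so the two numbers cannot be told apart. Compound 3 `Clc1ccc(C(c2c[nH]cc2-c2ccc(Cl)cc2-c2cccs2)n2ccnc2)c(Cl)c1` has not yet been measured. It carries thiophen-2-yl in place of 1H-pyrrol-1-yl on an aromatic carbon. Among the measured compounds shown here, no measured pair shows what such a swap does, so the expectation rests on compound 2 at 7670 nM, with no change beyond the scatter in this assay in either direction. The expected move is a 1.1-fold lower number from compound 2 to compound 3 (0.04 log units; within the scatter). For compound 3 the estimate is 7000 nM, with an expected range of 3000 nM to 16000 nM.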

Compound 3, half-maximal cytotoxic concentration: 4930 nM
For compound 3 the middle estimate is 1.4-fold (0.15 log units) above the measured one; measured number inside the range.
By their numbers in this assay, from the lowest: compounds 3, 2 and 1 (each within the scatter of the next, the first and the last beyond it).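

In this assay, among the compounds shown here, the swap of 1H-pyrrol-1-yl for thiophen-2-yl gives a 1.6-fold lower number from compound 2 to compound 3 (0.19 log units; within the scatter) and is the first comparison here of compounds that differ in one place. On this aromatic carbon, ortho to a large group, one five-membered aromatic ring with a nitrogen and one with a sulfur therefore cannot be told apart by this read-out. Nothing measured here gives a reason for this result.

On these data alone, what remains open is how a group without a ring, such as an amine or a carboxylic acid, would read at this same carbon.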